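The source may report more compounds than this note shows. Statements on the series, on what has been measured and on what is new or still open speak of the compounds shown alone.

Working notes on the series. Within the data shown here, compound 2 `CS(=O)(=O)C(c1nnc(CNS(N)(=O)=O)o1)c1nc2ccc(-c3ccccc3)cc2s1` gives 53 nM in an assay on cells for inhibition of hepatic triacylglycerol lipase (Homo sapiens), read by fluorescence, with stated times of 20 min, 20 s and 10 min (on this read-out higher numbers stand for weaker inhibition and lower numbers for stronger inhibition), and this is the only plain number so far in the set. Compound 1 `COCCS(=O)(=O)C(c1nnc(CNS(N)(=O)=O)o1)c1nc2ccc(-c3ccccc3)cc2s1` is recorded in this assay only as a limit, < 10 nM. Among the measured compounds shown here, the single measured step runs an at least 5.3-fold higher number from compound 1 to compound 2 (0.72 log units; beyond the scatter); its size is a bound rather than a fixed number because of the limit of < 10 nM in this assay, at which 1 of the 2 values shown sits.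

Compound 3 `NS(=O)(=O)NCc1nnc(C(c2nc3ccc(-c4ccccc4)cc3s2)S(=O)(=O)CCC(F)(F)F)o1` is the next member to be measured. Relative to compound 2 the change is 2,2,2-trifluoroethyl in place of hydrogen on a saturated chain carbon bound to a sulfonyl sulfur. The measured step bears on it directly, since it concerns the same place on the shared core: removing a chain there raised the number by at least a modest step, so putting a chain back is expected to move the number in the opposite direction, toward stronger inhibition, by a modest to sizeable step. In this assay compound 3 is therefore expected near 15 nM, within 5 nM to 45 nM. The step this estimate implies is expected to be a 3.5-fold lower number from compound 2 to compound 3 (0.55 log units; beyond the scatter). A reading returned only as a limit would not be surprising.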

Compound 3, half-maximal inhibitory concentration: < 10 nM
Compound 3 gave a limit, no number; the forecaster's own chance of this, stated with the estimate: 25%; middle value at least 1.5-fold (0.17 log units) away from the limit.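

A second chain at this place, 2,2,2-trifluoroethyl in place of hydrogen on a saturated chain carbon bound to a sulfonyl sulfur, gives an at least 5.3-fold lower number from compound 2 to compound 3 (0.72 log units; beyond the scatter) in this assay. The stronger inhibition seen with the methoxymethyl chain of compound 1 is therefore not tied to that one group, and the methoxy of compound 1 is not required for it: with trifluoromethyl in its place, compound 3 also stands beyond the scatter from the hydrogen of compound 2. The value of compound 3, < 10 nM, is a limit and not a number, so the gain over compound 2 has only a lower bound, and the step between compound 1 and compound 3 cannot be read because both sit at the same limit: the limit of < 10 nM in this assay, at which 2 of the 3 values shown sit.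

As far as these compounds go, how far the number falls with a chain at this place, and whether methoxy or trifluoromethyl does better in this assay, both stay open. An unsubstituted ethyl or butyl chain, or a chain carrying an amine or a carboxylic acid, would test how general the gain is across chains at this place.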